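Swapping a ketone-linked ring for a styryl arm

This account rests on a few compounds, and the source may have more. Where it says the series, first, only, none or still open, it means among the compounds named here.

Compound 3 `CCCCCCCCS(=O)(=O)Nc1ccc(C(=O)c2ccccc2OC)cc1C(=O)O` sits at the weak end of the small set measured so far. In an assay on mitochondria (strain BALB/c) for inhibition of glycerol-3-phosphate acyltransferase 1, mitochondrial (Mus musculus), read by scintillation counting, with a stated time of 10 min (on this read-out higher numbers stand for weaker inhibition and lower numbers for stronger inhibition), compound 3 gives 59200 nM, the highest number of the three. Compound 2 `CCCCCCCCS(=O)(=O)Nc1ccc(-c2ccc(O)cc2)cc1C(=O)O` gives 47300 nM, and the step of a 1.3-fold higher number from compound 2 to compound 3 (0.10 log units; within the scatter) lies within the scatter, so these two cannot be told apart. Compound 1 `CCCCCCCCS(=O)(=O)Nc1ccc(-c2ccccc2Cl)cc1C(=O)O` gives 14400 nM, and the step of a 4.1-fold higher number from compound 1 to compound 3 (0.61 log units; beyond the scatter) is beyond the scatter, so compound 3 is clearly weaker than compound 1.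

Compound 4 `CCCCCCCCS(=O)(=O)Nc1ccc(/C=C/c2ccccc2)cc1C(=O)O` differs from compound 3 in one place: 2-phenylethenyl in place of (2-methoxyphenyl)carbonyl on an aromatic carbon. Within the data shown here, the steps that bear on this are the ones where the group on the same aromatic carbon was changed: a 3.3-fold higher number from compound 1 to compound 2 (0.52 log units; beyond the scatter) and a 4.1-fold higher number from compound 1 to compound 3 (0.61 log units; beyond the scatter), both modest, together with the flat step a 1.3-fold higher number from compound 2 to compound 3 (0.10 log units; within the scatter). None of them tests a two-carbon link between the rings, so the evidence is indirect; compound 1, carrying a plain 2-chlorophenyl, gave the lowest number. A modest move toward that end is therefore expected: a 2.4-fold lower number from compound 3 to compound 4 (0.37 log units; beyond the scatter). Compound 4 is estimated at 25000 nM, within a range from 8000 nM to 80000 nM.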

Compound 4, half-maximal inhibitory concentration: 16300 nM
The estimate for compound 4 lay 1.5-fold (0.19 log units) above the measured number; the range from low to high includes it.
By their numbers in this assay, from the lowest: compounds 1 and 4 (each within the scatter of the next); then compounds 2 and 3 (each within the scatter of the next).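

Among these compounds, the 2-phenylethenyl group of compound 4 is the first arm at this aromatic carbon to match the 2-chlorophenyl of compound 1, with a 1.1-fold higher number from compound 1 to compound 4 (0.05 log units; within the scatter) in this assay, so the low end of this small set does not depend on a chlorine-bearing ring bonded directly to the core. The same group separates clearly from the two oxygen-bearing arms, with a 3.6-fold lower number from compound 3 to compound 4 (0.56 log units; beyond the scatter) and a 2.9-fold lower number from compound 2 to compound 4 (0.46 log units; beyond the scatter), so across these four compounds the two arms without oxygen give the lower numbers and the two with oxygen give the higher ones. No measurement here accounts for that split.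

A 2-phenylethyl group would show whether the double bond matters to this result. A 2-phenylethenyl arm with a methoxy group or an amine on its ring would test the oxygen split directly.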